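Aryl amine variation on the shared core: toward compound 4

This account rests on a few compounds, and the source may have more. Where it says the series, first, only, none or still open, it means among the compounds named here.

Three members of the series have numbers in a functional assay on HeLa cells (Homo sapiens) for inhibition, read by sulforhodamine B assay; a higher number here means a weaker inhibitor, a lower number a stronger inhibitor. Compound 1 `COc1ccccc1NC1=CC(=O)c2c(nc3n2[C@H]2OC[C@@H](O)[C@H]2OC3)C1=O` carries a 2-methoxyphenyl on the amine nitrogen; in this assay compound 1 gives 7460 nM, the highest of the three numbers. Compound 2 `CCOc1ccc(NC2=CC(=O)c3nc4n(c3C2=O)[C@H]2OC[C@@H](O)[C@H]2OC4)cc1` gives 3110 nM and compound 3 `Cc1ccc(NC2=CC(=O)c3nc4n(c3C2=O)[C@H]2OC[C@@H](O)[C@H]2OC4)cc1` gives 3860 nM. For the measured compounds named here, the one single-point step among them, a 1.2-fold higher number from compound 2 to compound 3 (0.09 log units; within the scatter), is within the scatter. The number of compound 1 stands beyond the scatter from that of compound 2, but within the scatter from that of compound 3.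

Compound 4 `O=C1C(Nc2cccc(F)c2)=CC(=O)c2c1nc1n2[C@H]2OC[C@@H](O)[C@H]2OC1` differs from compound 1 in one place: 3-fluorophenyl in place of 2-methoxyphenyl on an amine nitrogen. Going by the values given here, no measured step exchanges one aryl group for another in this way; the step from compound 2 to compound 3 only swaps a group on an aromatic carbon and stays within the scatter. The aryl variants so far occupy a narrow band, because compound 1 gives 7460 nM and compound 2 gives 3110 nM, so compound 4 is expected to land inside that band. For compound 4 the estimate in this assay is 5000 nM, with a range from 2000 nM to 14000 nM. The expected step of a 1.5-fold lower number from compound 1 to compound 4 (0.17 log units; within the scatter) is toward a somewhat lower number and may fall within the scatter.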

Compound 4, half-maximal inhibitory concentration: > 8000 nM
Compound 4: no number, only a limit (the forecaster's own chance of this, stated with the estimate: 5%); at least 1.6-fold (0.20 log units) between middle value and limit.
By their numbers in this assay, from the lowest: compounds 2, 3 and 1 (each within the scatter of the next, the first and the last beyond it). At a limit, above all of these: compound 4.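

Compound 4 gives > 8000 nM in this assay, which is a limit of the assay and not a number, and it is the only reading of this kind in the series so far: the limit of > 8000 nM in this assay, at which 1 of the 4 values shown sits. For the compounds shown here, the step at this amine nitrogen, an at least 1.0-fold higher number from compound 1 to compound 4 (0.03 log units; that floor lies within the scatter), is the first readable exchange of one aryl group for another on the shared core, whereas the step among the earlier compounds only swapped a group on an aromatic carbon. From the compounds shown here alone, this exchange of 2-methoxyphenyl for 3-fluorophenyl brings no lower number, yet its floor does not carry compound 4 beyond the scatter from compound 1, and how far the true value lies past the limit stays unknown.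

The exchange alters the substituent and its location on the ring together, so these two changes remain unseparated in the compounds shown. Also open, going by these compounds, is how the number moves with a non-aromatic group on this amine nitrogen, such as cyclohexyl or a longer alkyl chain, or with a carboxylic acid on the phenyl ring.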